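Swapping a Chlorophenyl for a Trifluoromethylphenyl on the Core

The source may report more compounds than this note shows. Statements on the series, on what has been measured and on what is new or still open speak of the compounds shown alone.

Compound 1 `Brc1cn2ccnc2c(-c2ccc3ncn(C4CCCCC4)c3c2)n1`: 7.68%
Compound 2 `Clc1ccc(-c2cn3ccnc3c(-c3ccc4ncn(C5CCCCC5)c4c3)n2)cc1`: 11.4%

In a functional assay on CCRF-CEM cells (Homo sapiens) for inhibition, read by sulforhodamine B assay, with a stated time of 48 h, tested at 10 uM (on this read-out lower numbers stand for less inhibition and higher numbers for more inhibition at the one concentration tested (going by the name of the read-out)), compound 1 gives 7.68%, and compound 2 gives 11.4%. Within the data shown here, compound 2 has the higher of the two numbers, but the single step of a number 3.7 percentage points higher from compound 1 to compound 2 (within the scatter) lies within the scatter, so the two cannot be ordered. Compound 3 `FC(F)(F)c1cccc(-c2cn3ccnc3c(-c3ccc4ncn(C5CCCCC5)c4c3)n2)c1` differs from compound 2 by 3-(trifluoromethyl)phenyl in place of 4-chlorophenyl on an aromatic carbon. Among the measured compounds shown here, no measured step swaps one aryl ring for another, so the only step seen bears on this change loosely. Compound 3 is therefore expected to sit near compound 2, at an estimated 13%, in the range 2% to 28%, a step of a number 1.6 percentage points higher from compound 2 to compound 3 (within the scatter) that is expected to stay within the scatter.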

Compound 3, a percentage reported as inhibition, at one concentration (the size of the read-out at that concentration, not a potency): 27.3%
Beside the measured number, compound 3's estimate is 14.3 percentage points below it; the measured number falls inside the stated range.
By their numbers in this assay, from the lowest: compounds 1 and 2 (each within the scatter of the next); then compound 3.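

In this assay, the group on this aromatic carbon of the core now clearly matters: 3-(trifluoromethyl)phenyl in place of 4-chlorophenyl gives a number 15.9 percentage points higher from compound 2 to compound 3 (beyond the scatter), and in place of bromo it gives a number 19.6 percentage points higher from compound 1 to compound 3 (beyond the scatter). Among these compounds, these are the first steps here to clear the scatter, though both are modest. Nothing measured here explains the gain. The step from compound 2 to compound 3 changes both the substituent and its place on the phenyl ring, so their contributions cannot be separated. Going by these compounds, what an amine or a carboxylic acid on that ring would do remains open.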